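Compound 3 and a methoxy swap

This account rests on a few compounds, and the source may have more. Where it says the series, first, only, none or still open, it means among the compounds named here.

- Compound 1 `CC(C(=O)SCCCCCCC(=O)Nc1nc(-c2ccccc2)cs1)c1ccccc1`: > 20000 nM; 27000 nM (2 entries)
- Compound 2 `C[C@@H](Cc1ccccc1)C(=O)SCCCCCCC(=O)Nc1nc(-c2ccccc2)cs1`: 4000 nM
- Compound 3 `CC(Cc1ccccc1)C(=O)SCCCCCCC(=O)Nc1nc(-c2ccccc2)cs1`: 1900 nM

Among the compounds with values here, in a functional assay on MDA-MB-231 cells (Homo sapiens) for inhibition (a higher number here means that more compound is needed for the effect, a lower number that less compound is needed), compound 3 gives 1900 nM, the lowest of the single numbers. Within the data shown here, the only measured single-place step is a 2.1-fold lower number from compound 2 to compound 3 (0.32 log units; beyond the scatter), and it rests on (the fact that one of compounds 2 and 3 is drawn with a defined configuration and the other without, at the place where they differ), so it says little about a new group. Compound 4 `COC(C(=O)SCCCCCCC(=O)Nc1nc(-c2ccccc2)cs1)c1ccccc1` differs at a carbonyl carbon: methoxy(phenyl)methyl in place of 1-benzylethyl on a carbonyl carbon, with methoxy(phenyl)methyl in place of 1-benzylethyl. Compound 1 also carries a different group on that carbonyl carbon. Compound 1 shows (the several entries of compound 1 in this assay, > 20000 nM; 27000 nM (2 entries)), one of them a limit. On the evidence of compound 1 with > 20000 nM; 27000 nM (2 entries), a clear rise is expected in this assay, much larger than the scatter. The expected change is a 6.3-fold higher number from compound 3 to compound 4 (0.80 log units; beyond the scatter). For compound 4 the estimated value is 12000 nM, with an expected range of 4000 nM to 30000 nM.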

Compound 4, half-maximal effective concentration: > 20000 nM
Compound 4 was reported as a limit; the forecaster's own chance of this, stated with the estimate: 30%; middle value at least 1.6-fold (0.22 log units) away from the limit.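

Replacing 1-benzylethyl with methoxy(phenyl)methyl on this carbonyl carbon gives, in this assay, an at least 10-fold higher number from compound 3 to compound 4 (1.02 log units; beyond the scatter) and an at least 5.0-fold higher number from compound 2 to compound 4 (0.69 log units; beyond the scatter). Compound 4 gives > 20000 nM, a limit of the assay and not a number. The two groups have the same number of heavy atoms and the same aromatic ring, so matching these counts did not keep the number low at this position.

The compounds shown leave open whether the single hydrogen-bond acceptor of the methoxy matters. They also leave open how an amine or a carboxylic acid in place of that methoxy would read.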